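Removing a ring-nitrogen methylsulfonyl: expected cytotoxicity shift

The source may report more compounds than this note shows. Statements on the series, on what has been measured and on what is new or still open speak of the compounds shown alone.

Compound 1 `Cc1cc(/C=C/C#N)cc(C)c1Oc1nc(Nc2ccc(CN3CCN(S(N)(=O)=O)CC3)cc2)nc2ccsc12`: 145000 nM
Compound 2 `Cc1cc(/C=C/C#N)cc(C)c1Oc1nc(Nc2ccc(CN3CCN(S(C)(=O)=O)CC3)cc2)nc2sccc12`: 131000 nM
Compound 3 `Cc1cc(/C=C/C#N)cc(C)c1Oc1nc(Nc2ccc(CN3CCNCC3)cc2)nc2ccsc12`: 3970 nM

In an ADME assay on MT4 cells (Homo sapiens) for cytotoxicity, read by MTT assay, with a stated time of 5 days (on this read-out lower numbers stand for higher toxicity in this test and higher numbers for lower toxicity in this test), compound 2 stands second highest of the three numbers, within the scatter of compound 1 and well above compound 3. Compound 4 `Cc1cc(/C=C/C#N)cc(C)c1Oc1nc(Nc2ccc(CN3CCNCC3)cc2)nc2sccc12` is the unmeasured analogue in which (hydrogen in place of methylsulfonyl on an amine nitrogen in a ring). Among the measured compounds shown here, the one measured step that bears on it, a 37-fold lower number from compound 1 to compound 3 (1.56 log units; beyond the scatter), is of the same kind and was large; compound 3 itself differs from compound 4 only in the shared core, and compounds 1 and 2 are indistinguishable in this assay. A comparable large downward step is therefore expected, and compound 4 is estimated at 4000 nM (range 1500 nM to 12000 nM), an expected step of a 33-fold lower number from compound 2 to compound 4 (1.52 log units; beyond the scatter).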

Compound 4, half-maximal cytotoxic concentration: 4030 nM
Compound 4: the middle estimate sits 1.0-fold (0.00 log units) below what was measured; low and high end bracket the measured number.
By their numbers in this assay, from the lowest: compounds 3 and 4 (each within the scatter of the next); then compounds 2 and 1 (each within the scatter of the next).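

In this assay, hydrogen in place of methylsulfonyl on an amine nitrogen in a ring gives a 33-fold lower number from compound 2 to compound 4 (1.51 log units; beyond the scatter), a large step. Among the compounds shown here, a large step at this nitrogen had so far been seen only with sulfamoyl, a 37-fold lower number from compound 1 to compound 3 (1.56 log units; beyond the scatter), so it now holds for two different groups, each on its own form of the core. Nothing available here accounts for the size of either step.

From the compounds shown here alone, it remains open whether a methyl or acetyl group on the same nitrogen would read like compound 1 and compound 2 or like compound 3 and compound 4.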